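Propyl to hydrogen on the phenyl: compound 1 to compound 4

The compounds below may be only part of what the source reports. "The series", "measured", "known", "first", "only" and "open" are said of these compounds alone.

Measured so far:
compound 1 `CCCc1ccc(/C=C/C(=O)Nc2ccc3nc(CCC)cc(N)c3c2)cc1`: 4 nM
compound 2 `CCCc1cc(NC2CC2)c2cc(NC(=O)/C=C/c3ccc(C(F)(F)F)cc3)ccc2n1`: 40 nM
compound 3 `CCCc1cc(N)c2cc(NC(=O)c3ccc(C(F)(F)F)cc3)ccc2n1`: 10000 nM

Three compounds have a number in an assay on isolated protein for displacement of a labelled ligand from melanin-concentrating hormone receptor 1 (Homo sapiens); a lower number here means a stronger inhibitor, a higher number a weaker inhibitor. Compound 1 stands at the lowest of the three numbers. Compound 2 is its nearest neighbour and lies higher, beyond the usual scatter; compound 3 lies far higher still, well beyond the scatter. Compound 2 and compound 3 differ from compound 1 in more than one place, so their values show only where they stand, not what any single change does.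

Compound 4 `CCCc1cc(N)c2cc(NC(=O)/C=C/c3ccccc3)ccc2n1` is the next compound to be measured in this assay. It differs from compound 1 in one place: hydrogen in place of propyl on an aromatic carbon. Within the data shown here, no step between measured compounds isolates this change, so the expectation rests on the position of compound 1 alone. Among the measured compounds shown here, a moderate rise in the number is expected, as the step of a 10-fold higher number from compound 1 to compound 4 (1.00 log units; beyond the scatter), since the propyl is the only group removed from the phenyl that in compound 1 gives 4 nM. Compound 4 is therefore estimated at 40 nM, with a range from 8 nM to 200 nM.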

Compound 4, half-maximal inhibitory concentration: 1000 nM
Beside the measured number, compound 4's estimate is 25-fold (1.40 log units) below it; measured number outside the range, above it.
By their numbers in this assay, from the lowest: compound 1; then compound 2; then compound 4; then compound 3.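

In this assay, among these compounds, replacing 4-propylphenyl with phenyl gives a 250-fold higher number from compound 1 to compound 4 (2.40 log units; beyond the scatter), the first reading of a single change. The position para to a large group is therefore far from indifferent to its substituent, and most of the low number of compound 1 is lost when the propyl leaves. No accompanying measurement bears on the size of this step.

From the compounds shown here alone, whether the number tracks chain length remains open, as an ethyl or a butyl at this place would show, and an amine or a methoxy group would test whether a carbon chain is needed at all. Trifluoromethyl at this place occurs only in compound 2 and compound 3, which also differ elsewhere, so it cannot be read against propyl or hydrogen.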